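The compounds below may be only part of what the source reports. "The series", "measured", "known", "first", "only" and "open" are said of these compounds alone.

Compound 2 `COC(=O)c1ccc(-c2ccc(CN3CCCN(C)CC3)cc2)cc1` in an assay on isolated protein for inhibition of choline kinase alpha (Homo sapiens), with a stated time of 30 min (a lower number here means a stronger inhibitor, a higher number a weaker inhibitor), gives 4950 nM, the higher of the two numbers in hand. Compound 1 `COc1ccc(-c2ccc(CN3CCCN(C)CC3)cc2)cc1` gives 1430 nM; the step of a 3.5-fold higher number from compound 1 to compound 2 (0.54 log units; beyond the scatter) shows that replacing methoxy with methoxycarbonyl weakened inhibition. Compound 3 `CN1CCCN(Cc2ccc(-c3ccc(CN4CCCN(C)CC4)cc3)cc2)CC1` carries (4-methyl-1,4-diazepan-1-yl)methyl in place of methoxycarbonyl on an aromatic carbon. Going by the values given here, no measured step covers this new group, and the one measured step bears only in that it removes the methoxycarbonyl which cost potency from compound 1 to compound 2. For compound 3 a step of a 9.9-fold lower number from compound 2 to compound 3 (1.00 log units; beyond the scatter) toward a lower number is therefore expected, though its size is uncertain. The estimate for compound 3 in this assay is 500 nM, with a range of 100 nM to 2500 nM.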

Compound 3, half-maximal inhibitory concentration: 457 nM
Estimate against measurement, compound 3: 1.1-fold (0.04 log units) above; low and high end bracket the measured number.
By their numbers in this assay, from the lowest: compound 3; then compound 1; then compound 2.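

In this assay, (4-methyl-1,4-diazepan-1-yl)methyl in place of methoxycarbonyl gives an 11-fold lower number from compound 2 to compound 3 (1.03 log units; beyond the scatter) and in place of methoxy gives a 3.1-fold lower number from compound 1 to compound 3 (0.50 log units; beyond the scatter) on the same aromatic carbon. This position, para to a large group, therefore accepts a much larger group with a seven-membered ring, and the number falls below those of both smaller groups. Nothing measured here accounts for this gain.

Going by these compounds, whether the gain depends on the seven-membered ring or on its nitrogens remains open. A piperidin-1-ylmethyl or a simple aminomethyl group here would separate the two.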